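The source may hold more compounds than are shown below. What is called first, only, known or untested is meant among the compounds shown, and "the series" means these compounds.

Compound 1, `COc1ncc(-c2ccc3c(c2)N(c2ccc(C)cc2)C(=O)CO3)cc1NS(=O)(=O)c1ccc(F)cc1`: 5870 nM
Compound 2, `Cc1ccc(N2C(=O)COc3ccc(-c4cnc(Cl)c(NS(=O)(=O)c5ccc(F)cc5)c4)cc32)cc1`: 30900 nM
Compound 3, `O=C1COc2ccc(-c3cccc(NS(=O)(=O)c4ccc(F)cc4)c3)cc2N1C1CCCCC1`: 14500 nM

In a functional assay on A549 cells (Homo sapiens) for antiproliferative activity, read by MTT assay, with a stated time of 72 h (a higher number here means a weaker inhibitor, a lower number a stronger inhibitor), compound 1 gives the lowest of the three numbers shown; compound 3 stands nearest to it with a higher number, and compound 2 stands furthest with a still higher one. Compound 4, `COc1cccc(N2C(=O)COc3ccc(-c4cnc(OC)c(NS(=O)(=O)c5ccc(F)cc5)c4)cc32)c1`, has not yet been measured. It differs from compound 1 in one place: 3-methoxyphenyl in place of 4-methylphenyl on an amide-type nitrogen in a ring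

Among the compounds with values here, the only single-point step among the measured compounds is a 5.3-fold higher number from compound 1 to compound 2 (0.72 log units; beyond the scatter), which concerns a different part of the molecule, the substituent on an aromatic carbon rather than the group on the amide-type nitrogen in a ring. Compound 3 also carries a different group on that nitrogen, a cyclohexyl, but it differs from compound 1 elsewhere as well, so its value alone cannot be read as a step for the nitrogen substituent. Within the data shown here, no measured step therefore bears directly on the exchange of 4-methylphenyl for 3-methoxyphenyl. With no guidance in either direction, the change is expected to leave the number near that of compound 1, within the scatter, as expressed by a 1.2-fold higher number from compound 1 to compound 4 (0.08 log units; within the scatter). Compound 4 is thus estimated at 7000 nM, with a range from 2500 nM to 20000 nM.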

Compound 4, half-maximal inhibitory concentration: 11200 nM
Compound 4: the middle estimate sits 1.6-fold (0.20 log units) below what was measured; the measured number falls inside the stated range.
By their numbers in this assay, from the lowest: compounds 1, 4 and 3 (each within the scatter of the next, the first and the last beyond it); then compound 2.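

In this assay the first step read at the amide-type nitrogen in a ring is a 1.9-fold higher number from compound 1 to compound 4 (0.28 log units; within the scatter), with 3-methoxyphenyl in place of 4-methylphenyl, so this read-out does not tell the two groups apart. Within the data shown here, the position therefore accepts a group carrying an oxygen and a hydrogen-bond acceptor, which 4-methylphenyl lacks, with a step that stays within the scatter, whereas the only earlier step, a 5.3-fold higher number from compound 1 to compound 2 (0.72 log units; beyond the scatter), concerned a substituent on an aromatic carbon and lay beyond it. Nothing measured here offers a reason for this result.

The compounds shown leave open whether this tolerance extends to other groups on the same nitrogen, such as a benzyl group, or to a phenyl ring bearing a primary amine or a carboxylic acid. They also leave open whether exchanging 4-methylphenyl for 3-methoxyphenyl would read the same way with chloro rather than methoxy on the aromatic carbon, since the two changes are seen here only one at a time.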